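A few compounds are considered here, and "the series" means these few. Any claim that something is new, unique, unknown or untested is made for them only; others in the source may bear on it.

Measured in a functional assay on DU-145 cells (Homo sapiens) for cytotoxicity, read by MTT assay; a higher number here means a weaker inhibitor, a lower number a stronger inhibitor:
- compound 1 `CC(C)=CC[C@@H](OCC(C)O)C1=CC(=O)c2c(O)ccc(O)c2C1=O`: 16100 nM
- compound 2 `CC(C)=CC[C@@H](OCCO)C1=CC(=O)c2c(O)ccc(O)c2C1=O`: 9900 nM

Going by the values given here, compound 2, at 9900 nM, cannot be separated from its only measured neighbour, compound 1. The step of a 1.6-fold lower number from compound 1 to compound 2 (0.21 log units; within the scatter) lies within the scatter in this assay.

Compound 3 `CCC(C)(O)CC(=O)O[C@H](CC=C(C)C)C1=CC(=O)c2c(O)ccc(O)c2C1=O` has not yet been measured. It carries (2-hydroxy-2-methylbutyl)carbonyl in place of 2-hydroxyethyl on an oxygen on a saturated carbon.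

This is a much larger change than the only measured one, which puts hydrogen in place of methyl on the saturated chain. That step, a 1.6-fold lower number from compound 1 to compound 2 (0.21 log units; within the scatter), shows only that this small edit left the number within the scatter. Among the compounds with values here, no measured compound carries the entering group, so the data give neither a size nor a direction for the new change. The working expectation therefore stays close to compound 2, with no shift beyond the scatter and with wide uncertainty on both sides. The expected change is a 1.2-fold lower number from compound 2 to compound 3 (0.09 log units; within the scatter). For compound 3 the estimated value is 8000 nM, with an expected range of 2500 nM to 20000 nM.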

Compound 3, half-maximal inhibitory concentration: 16000 nM
Compound 3: middle estimate off by 2.0-fold (0.30 log units), on the low side; the measured number falls inside the stated range.
By their numbers in this assay, from the lowest: compounds 2, 3 and 1 (each within the scatter of the next).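

In this assay, the change on the oxygen on a saturated carbon is now far larger than the earlier methyl-to-hydrogen edit: 2-hydroxyethyl with 3 heavy atoms gives way to (2-hydroxy-2-methylbutyl)carbonyl with 8 heavy atoms, a carbonyl double bond and one further hydrogen-bond acceptor, yet the result is a 1.6-fold higher number from compound 2 to compound 3 (0.21 log units; within the scatter). Measured against the 2-hydroxypropyl group, the same entering group gives a 1.0-fold lower number from compound 1 to compound 3 (0.00 log units; within the scatter), so all three groups on this oxygen remain inseparable in this assay, and neither the added size nor the carbonyl produces a step beyond the scatter in these compounds. No available evidence bears on why these groups read alike.

Every group compared here carries a hydroxyl, so a plain butyl chain, an aminoethyl group or a carboxylic acid on this oxygen would test whether that shared hydroxyl matters. Going by these compounds, whether any replacement at this position can move the number beyond the scatter, in either direction, remains open.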